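The compounds below may be only part of what the source reports. "The series", "measured", "known", "first", "only" and "open" are said of these compounds alone.

Measured compounds:
Compound 1, `Cc1ccc(-c2nn(-c3ccc(F)cc3F)cc2CNCCN2CCN(C)CC2)cc1`: in an ADME assay on Huh-7 cells (Homo sapiens) for cytotoxicity (a higher number here means that more compound is tolerated, a lower number that less compound is tolerated), compound 1 gives > 20000 nM, a limit of the assay.
Compound 2, `COC(=O)c1ccc(-c2nn(-c3ccc(F)cc3F)cc2CNCCN2CCN(C)CC2)cc1`: in this assay compound 2 gives > 20000 nM, a limit of the assay.
Compound 3, `CN1CCN(CCNCc2cn(-c3ccc(F)cc3F)nc2-c2ccc(S(=O)(=O)N(C)C)cc2)CC1`: in this assay compound 3 gives > 20000 nM, a limit of the assay.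

Compound 3 stands at the limit, and the two further values shown also sit there (the limit of > 20000 nM in this assay, at which 3 of the 3 values shown sit). The steps a step that the two limits leave unreadable from compound 1 to compound 3 and a step that the two limits leave unreadable from compound 2 to compound 3 are therefore unreadable in size; the same holds for a step that the two limits leave unreadable from compound 1 to compound 2. Compound 4, `Cc1cccc(-c2nn(-c3ccc(F)cc3F)cc2CNCCN2CCN(C)CC2)c1`, is still to be measured. The change is 3-methylphenyl in place of 4-(dimethylsulfamoyl)phenyl on an aromatic carbon. No measured step bears on this change with a readable size: all that is shown is that aromatic carbon substituents of three kinds, methyl, methoxycarbonyl and dimethylsulfamoyl, all leave the compounds at the limit. Compound 4 is expected to behave the same way, with a step that the limit leaves unreadable from compound 3 to compound 4 not beyond the scatter. Compound 4 is estimated at 30000 nM, within 15000 nM to 80000 nM, most likely again reported only as a limit.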

Compound 4, half-maximal cytotoxic concentration: > 20000 nM
Compound 4 ended at the assay's limit; the forecaster's own chance of this, stated with the estimate: 85%; the middle value is on the limit's open side.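

Compound 4 joins compound 1, compound 2 and compound 3 at the assay's limit, so no step among these compounds can be read in this assay: the limit of > 20000 nM in this assay, at which 4 of the 4 values shown sit. The compounds shown leave open whether changing the aryl group on the shared core alters tolerated concentration at all.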